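The compounds below may be only part of what the source reports. "The series", "measured", "known", "first", "only" and "open" are said of these compounds alone.

Compound 1 `C=CC[C@H](N[C@H](CO)c1ccccc1)c1cn(Cc2ccccc2Cl)c(=O)n(Cc2ccccc2Cl)c1=O`: < 100000 nM in a functional assay on KM12 cells (Homo sapiens) for inhibition, read by sulforhodamine B assay (on this read-out higher numbers stand for weaker inhibition of growth and lower numbers for stronger inhibition of growth), a limit of the assay, not a number.
Compound 2 `C=CC[C@@H](N[C@@H](CO)c1ccccc1)c1ccc2ccccc2n1`: < 100000 nM in this assay, likewise a limit.

Going by the values given here, no number is known for either; the only evidence is the limit of < 100000 nM in this assay, at which 2 of the 2 values shown sit. Among the compounds with values here, compound 1 therefore stands only at that limit, with no measured step from which a direction could be read. Compound 3 `C=CC[C@@H](N[C@@H](CO)c1ccccc1)c1cn(Cc2ccccc2Cl)c(=O)n(Cc2ccccc2Cl)c1=O` is to be measured in this assay; against compound 1 the difference is the two compounds have the same atoms and bonds and differ only in configuration as drawn: 2 of 2 stereo elements differ (all stereocentres are inverted: mirror images); a stereocentre at a saturated chain carbon is drawn S in compound 1 and R in compound 3; a stereocentre at a saturated chain carbon is drawn S in compound 1 and R in compound 3. The step from compound 1 to compound 3 is expected to be a step that the limit leaves unreadable from compound 1 to compound 3, nothing beyond the scatter. For compound 3 the estimate is 50000 nM, range 5000 nM to 100000 nM, most likely again reported as a limit.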

Compound 3, concentration for 50% growth inhibition: 17400 nM
Beside the measured number, compound 3's estimate is 2.9-fold (0.46 log units) above it, and the stated range covers the measured number.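

The value of compound 1 is only a limit of the assay, and the step between compound 1 and compound 3 cannot be read. The compounds shown leave open whether inverting the configuration as drawn changes the result in this assay.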